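Swapping a methyl for trifluoromethoxy on the anilino ring

The compounds below may be only part of what the source reports. "The series", "measured", "known", "first", "only" and "open" are said of these compounds alone.

Compound 1 `CCCCOC1=C(C(=O)c2ccccc2)C(c2ccc(Br)cc2)N(CCCn2ccnc2)C1=O` gives 17100 nM in a functional assay on NCI-H1299 cells (Homo sapiens) for antiproliferative activity, read by MTT assay, with a stated time of 72 h; on this read-out lower numbers stand for stronger inhibition and higher numbers for weaker inhibition; compound 2 `Cc1ccc(NC2=C(C(=O)c3ccccc3)C(c3ccc(Br)cc3)N(CCCn3ccnc3)C2=O)cc1` gives 25800 nM, the higher of the two numbers, with a 1.5-fold higher number from compound 1 to compound 2 (0.18 log units; within the scatter). Compound 3 `O=C(C1=C(Nc2ccc(OC(F)(F)F)cc2)C(=O)N(CCCn2ccnc2)C1c1ccc(Br)cc1)c1ccccc1` differs from compound 2 by trifluoromethoxy in place of methyl on an aromatic carbon. Within the data shown here, no measured step touches this position; the only known step, the exchange of butoxy for (4-methylphenyl)amino, changed the number little. With nothing pointing either way, compound 3 is expected to stay close to compound 2, a step of a 1.0-fold lower number from compound 2 to compound 3 (0.01 log units; within the scatter) in this assay . The estimate for compound 3 is 25000 nM, with a range from 8000 nM to 70000 nM.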

Compound 3, half-maximal inhibitory concentration: 11500 nM
For compound 3 the middle estimate is 2.2-fold (0.34 log units) above the measured one; the measured number falls inside the stated range.
By their numbers in this assay, from the lowest: compounds 3, 1 and 2 (each within the scatter of the next, the first and the last beyond it).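

In this assay, the group on this aromatic carbon does affect the number: trifluoromethoxy in place of methyl gives a 2.2-fold lower number from compound 2 to compound 3 (0.35 log units; beyond the scatter), a modest step but the first one here beyond the scatter. Replacing butoxy with (4-(trifluoromethoxy)phenyl)amino gives a 1.5-fold lower number from compound 1 to compound 3 (0.17 log units; within the scatter), so that exchange still shows no clear change. Nothing available here explains the step from methyl to trifluoromethoxy. From the compounds shown here alone, whether a chlorine atom, a methoxy group or an amine on the same carbon would give a similar number remains open.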